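Aryl ketone swap on the shared core

A few compounds are considered here, and "the series" means these few. Any claim that something is new, unique, unknown or untested is made for them only; others in the source may bear on it.

Compound 2 `COc1cccc(C(=O)CC2C(C#N)=C(N)Oc3ccc(Br)cc32)c1` is one of two measured members of the series. In a functional assay on MCF7 cells (Homo sapiens) for antiproliferative activity, read by sulforhodamine B assay, with a stated time of 72 h, tested at 30 uM (on this read-out higher numbers stand for a weaker effect at the one concentration tested and lower numbers for a stronger effect), compound 2 gives 34.4%. Compound 1 `COC(=O)C1=C(N)Oc2ccc(Br)cc2C1CC(=O)c1ccc(Br)cc1` in this assay gives 34.8%; the two numbers lie within the scatter of each other, so neither stands apart. Compound 3 `Cc1ccc(C(=O)CC2C(C#N)=C(N)Oc3ccc(Br)cc32)cc1` is not yet measured and differs from compound 2 in one place: 4-methylphenyl in place of 3-methoxyphenyl on a carbonyl carbon. Going by the values given here, no measured pair shows the effect of such a change, and the two numbers at hand point in no direction, so the expected step is a number 1.6 percentage points higher from compound 2 to compound 3 (within the scatter), none beyond the scatter. For compound 3 the estimate in this assay is 36%, with a range from 20% to 55%.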

Compound 3, a percentage reported as activity, at one concentration (the size of the read-out at that concentration, not a potency): 32.3%
Compound 3: middle estimate off by 3.7 percentage points, on the high side; low and high end bracket the measured number.
By their numbers in this assay, from the lowest: compounds 3, 2 and 1 (each within the scatter of the next).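

Putting 4-methylphenyl in place of 3-methoxyphenyl on a carbonyl carbon gives a number 2.1 percentage points lower from compound 2 to compound 3 (within the scatter) in this assay as the first step read at this position. This change of aryl group therefore leaves the read-out within the scatter on the shared core with the nitrile. Nothing measured bears on a cause for this result.

As far as these compounds go, it remains open whether an amine or a carboxylic acid on this aryl ring would move the number beyond the scatter. From the compounds shown here alone, a longer chain in place of the aryl group is equally open.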